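From nitro to methoxy on a shared core

The compounds below may be only part of what the source reports. "The series", "measured", "known", "first", "only" and "open" are said of these compounds alone.

Compound 1 `COc1cc(-c2ncnn2-c2cccc(N)c2)cc(OC)c1OC`: > 10000 nM
Compound 2 `COc1cc(-c2ncnn2-c2ccc([N+](=O)[O-])cc2)cc(OC)c1OC`: > 10000 nM
Compound 3 `COc1cc(-n2ncnc2-c2ccccc2)cc(OC)c1OC`: > 10000 nM

The three compounds were tested in a functional assay on A549 cells (Homo sapiens) for antiproliferative activity, read by MTT assay, with a stated time of 72 h (a lower number here means a stronger inhibitor, a higher number a weaker inhibitor), and each reading is a limit, not a number: the limit of > 10000 nM in this assay, at which 3 of the 3 values shown sit. Compound 2 stands only at its limit of > 10000 nM. Compound 4 `COc1ccc(-n2ncnc2-c2cc(OC)c(OC)c(OC)c2)cc1` shares the core of compound 2 and differs in one group: methoxy in place of nitro on an aromatic carbon. It carries methoxy in place of nitro on an aromatic carbon. Among the measured compounds shown here, no measured pair shows the effect of this change, so the estimate is uncertain. What is expected is an at least 10-fold lower number from compound 2 to compound 4 (1.00 log units; beyond the scatter), toward a stronger inhibitor and beyond the scatter. Compound 4 might still remain at the limit. For compound 4 the estimated value is 1000 nM, with an expected range from 50 nM to 10000 nM.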

Compound 4, half-maximal inhibitory concentration: > 10000 nM
Compound 4 gave a limit, no number; the forecaster's own chance of this, stated with the estimate: 30%; middle value at least 10-fold (1.00 log units) away from the limit.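

Neither the step from compound 2 to compound 4 nor the one from compound 1 to compound 4 can be read, because each compound gives only a limit: the limit of > 10000 nM in this assay, at which 4 of the 4 values shown sit.

Whether methoxy in place of nitro changes activity at all, and how strong any of these compounds is, stays open.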